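A few compounds are considered here, and "the series" means these few. Any claim that something is new, unique, unknown or untested is made for them only; others in the source may bear on it.

Measured compounds:
compound 1 `COc1ccc(-c2cn(C/C=C3\OC(=O)C(OCc4ccccc4)=C3OCc3ccccc3)nn2)cc1` — > 100000 nM
compound 2 `Cc1ccc(S(=O)(=O)NCc2cn(C[C@H](O)[C@H]3OC(=O)C(OCc4ccccc4)=C3OCc3ccccc3)nn2)cc1` — 14400 nM
compound 3 `O=C1O[C@H]([C@@H](O)Cn2cc(CNS(=O)(=O)c3ccc(Cl)cc3F)nn2)C(OCc2ccccc2)=C1OCc1ccccc1` — 20700 nM

In a functional assay on HeLa cells (Homo sapiens) for antiproliferative activity, read by MTT assay, with a stated time of 72 h (on this read-out higher numbers stand for weaker inhibition and lower numbers for stronger inhibition), compound 1 gives > 100000 nM, which is a limit of the assay and not a number. Compound 1 therefore sits at the limit of > 100000 nM in this assay, at which 1 of the 3 values shown sits, the weakest end of the numbers shown. Compound 2 and compound 3 share a core carrying a hydroxyl and a sulfonamide, and between them a 1.4-fold higher number from compound 2 to compound 3 (0.16 log units; within the scatter).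

Compound 4 `O=C1O/C(=C\Cn2cc(-c3ccc(Br)cc3)nn2)C(OCc2ccccc2)=C1OCc1ccccc1` is compound 1 with bromo in place of methoxy on an aromatic carbon, the difference read one bond further out being 4-methoxyphenyl to 4-bromophenyl. No measured step touches this change: the only step shown, a 1.4-fold higher number from compound 2 to compound 3 (0.16 log units; within the scatter), swaps an aryl on a sulfonyl sulfur on a different core and says nothing about a methoxy-to-bromo exchange on a triazole-linked aryl. With compound 1 at a limit and no step beyond the scatter anywhere in the set, no step beyond the scatter is expected from compound 1 to compound 4, so compound 4 is expected to remain at or near the limit as well.

For compound 4 the estimate is 150000 nM (range 50000 nM to 500000 nM), meaning an expected step that the limit leaves unreadable from compound 1 to compound 4.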

Compound 4, half-maximal inhibitory concentration: 24300 nM
Beside the measured number, compound 4's estimate is 6.2-fold (0.79 log units) above it, and the stated range ends above it.
By their numbers in this assay, from the lowest: compounds 2, 3 and 4 (each within the scatter of the next). At a limit, above all of these: compound 1.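

In this assay, going by these compounds alone, the change from 4-methoxyphenyl to 4-bromophenyl gives the only step that lies beyond the scatter: an at least 4.1-fold lower number from compound 1 to compound 4 (0.61 log units; beyond the scatter). Within the data shown here, this place on the aromatic ring therefore affects the read-out on the core of compound 1, which the one earlier step, an aryl swap on a sulfonyl sulfur on a different core, could not show. Compound 1 stands at a limit and not at a number, so the true size of the step cannot be read: the limit of > 100000 nM in this assay, at which 1 of the 4 values shown sits.

As far as these compounds go, the two compounds do not explain why bromo and methoxy differ here, and it remains open how an amine, a nitrile or a carboxylic acid at this place would read. Also open, from the compounds shown here alone, is whether bromo would give a similar step on the core carrying the hydroxyl and the sulfonamide.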